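From 4-fluorophenyl to 3-chlorophenyl in an antiproliferative series

The compounds below may be only part of what the source reports. "The series", "measured", "known", "first", "only" and "open" are said of these compounds alone.

These compounds share one core and differ in the aromatic group on it. In a functional assay on MCF7 cells (Homo sapiens) for antiproliferative activity, read by MTT assay, with a stated time of 48 h (a lower number here means a stronger inhibitor, a higher number a weaker inhibitor), compound 1 `COC(=O)/C(=C/c1ccccc1)CN1C(=O)[C@@H](OC)[C@H]1c1ccc(Cl)cc1` gives 15300 nM as its result. Compound 3 `COC(=O)/C(=C/c1ccccc1)CN1C(=O)[C@@H](OC)[C@H]1c1ccc(F)cc1` gives 15600 nM in the same test, so the two stand level within the usual scatter. Compound 2 `COC(=O)/C(=C/c1ccccc1)CN1C(=O)[C@@H](OC)[C@H]1c1ccccc1C(F)(F)F` has no result reported, which leaves only these two numbers to compare. The change to compound 4 `COC(=O)/C(=C/c1ccccc1)CN1C(=O)[C@@H](OC)[C@H]1c1cccc(Cl)c1` is 3-chlorophenyl in place of 4-fluorophenyl on a saturated ring carbon and puts 3-chlorophenyl in place of 4-fluorophenyl on a saturated ring carbon. Among the compounds with values here, the only measured step that bears on it is a 1.0-fold higher number from compound 1 to compound 3 (0.01 log units; within the scatter) for fluoro in place of chloro on an aromatic carbon. Within the data shown here, since a 1.0-fold higher number from compound 1 to compound 3 (0.01 log units; within the scatter) stayed within the scatter, no step beyond it is expected in this assay for this change, although no measured compound carries 3-chlorophenyl. The estimated step is a 1.1-fold lower number from compound 3 to compound 4 (0.05 log units; within the scatter) in size. For compound 4 the estimate is 14000 nM with an expected range from 6000 nM to 30000 nM in this test.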

Compound 4, half-maximal inhibitory concentration: 25100 nM
For compound 4 the middle estimate is 1.8-fold (0.25 log units) below the measured one; the range from low to high includes it.
By their numbers in this assay, from the lowest: compounds 1, 3 and 4 (each within the scatter of the next).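

In this assay, putting 3-chlorophenyl in place of 4-fluorophenyl gives a 1.6-fold higher number from compound 3 to compound 4 (0.21 log units; within the scatter), and putting it in place of 4-chlorophenyl gives a 1.6-fold higher number from compound 1 to compound 4 (0.21 log units; within the scatter). The second pair is the new information: it changes only where the chlorine sits on the phenyl group, and even that leaves the result within the scatter, so all three halogen-bearing phenyl groups at this saturated ring carbon stand level. No measurement shown here explains why these results stay so close.

Compound 2 has no result reported, so any step involving it cannot be read. As far as these compounds go, it also remains open whether a phenyl group carrying an amine or a carboxylic acid, or a longer chain in place of the phenyl group, would move the result beyond the scatter.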